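Removing the methoxy from compound 2: cytotoxicity outlook

The source may hold more compounds than are shown below. What is called first, only, known or untested is meant among the compounds shown, and "the series" means these compounds.

Working notes on the series. Compound 1 `CC1=C(C(O)Cc2ccc(C(C)(C)C)cc2)C(C)(C)CCC1` in an ADME assay on HepG2 cells (Homo sapiens) for cytotoxicity, read by MTT assay, with a stated time of 24 h (on this read-out lower numbers stand for higher toxicity in this test and higher numbers for lower toxicity in this test), gives > 100000 nM, a limit of the assay rather than a number. Compound 2 `COc1cccc(CC(O)C2=C(C)CCCC2(C)C)c1` in this assay gives > 100000 nM, likewise only a limit. Compound 2 thus stands where every recorded value sits, because of the limit of > 100000 nM in this assay, at which 2 of the 2 values shown sit. Compound 3 `CC1=C(C(O)Cc2ccccc2)C(C)(C)CCC1` differs from compound 2 by hydrogen in place of methoxy on an aromatic carbon. Among the measured compounds shown here, no measured step exists for this change. The expected step that the limit leaves unreadable from compound 2 to compound 3 is nothing beyond the usual scatter. Compound 3 is therefore estimated at 150000 nM, range 60000 nM to 400000 nM, most likely again only a limit.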

Compound 3, half-maximal cytotoxic concentration: > 100000 nM
Compound 3: a limit, no number; the forecaster's own chance of this, stated with the estimate: 80%; the middle value is on the limit's open side.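

No step can be read among compound 1, compound 2 and compound 3 in this assay, because all three rest on the same limit: the limit of > 100000 nM in this assay, at which 3 of the 3 values shown sit. The compounds shown leave open where their true values lie, and whether methoxy or tert-butyl changes cytotoxicity at all.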